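Adding a methyl group to the tetrabrominated core

The compounds below may be only part of what the source reports. "The series", "measured", "known", "first", "only" and "open" are said of these compounds alone.

Of the compounds shown here, three sharing a tetrabrominated core have been measured in a functional assay on MCF7 cells (Homo sapiens) for cytotoxicity, read by MTT assay, with a stated time of 24 h, tested at 10 uM; a higher number here means a weaker effect of the compound at the concentration tested, a lower number a stronger effect. Compound 1, `Cc1nc2c(Br)c(Br)c(Br)c(Br)c2n1CC#N`, gives 52%. Compound 2, `Cc1nc2c(Br)c(Br)c(Br)c(Br)c2n1CCCCC#N`, gives 109%. Compound 3, `N#CCCn1cnc2c(Br)c(Br)c(Br)c(Br)c21`, gives 81%. On these numbers compound 3 stands second highest of the three: compound 2 lies above it beyond the scatter, and compound 1 lies below it beyond the scatter. Among the measured compounds shown here, the one measured step, a number 57 percentage points higher from compound 1 to compound 2 (beyond the scatter), concerns only the length of the nitrile-bearing chain on the ring nitrogen.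

Compound 4, `Cc1nc2c(Br)c(Br)c(Br)c(Br)c2n1CCC#N`, differs from compound 3 in a single place: methyl in place of hydrogen on an aromatic carbon. The change sits on an aromatic carbon of a five-membered aromatic ring with two nitrogen atoms, between two ring nitrogen atoms, while the 2-cyanoethyl group of compound 3 is kept. For the measured compounds named here, no measured step in this assay bears on this change; compounds 1 and 2 already carry the methyl group but differ from each other in the chain, not in the methyl. With nothing to indicate a direction, the step of a number 1 percentage points lower from compound 3 to compound 4 (within the scatter) is expected to stay within the scatter. Compound 4 is therefore estimated at 80%, in a range from 60% to 100%.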

Compound 4, a percentage reported as activity, at one concentration (the size of the read-out at that concentration, not a potency): 85%
Estimate against measurement, compound 4: 5 percentage points below; measured number inside the range.
By their numbers in this assay, from the lowest: compound 1; then compounds 3 and 4 (each within the scatter of the next); then compound 2.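

In this assay, methyl in place of hydrogen on the aromatic carbon between two ring nitrogen atoms gives a number 4 percentage points higher from compound 3 to compound 4 (within the scatter) and so, for this one pair with the 2-cyanoethyl group kept, the methyl group makes no difference that can be told from scatter. Compound 4 also adds a middle chain length to the methyl-bearing compounds, with a number 33 percentage points higher from compound 1 to compound 4 (beyond the scatter) on one side and a number 24 percentage points lower from compound 2 to compound 4 (beyond the scatter) on the other. Across these three compounds, none of which goes against the trend, the number rises as the nitrile-bearing chain on the ring nitrogen grows longer, which means that a weaker effect at the tested concentration goes with a longer chain, while the methyl change alone shows no such shift.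

Nothing measured here explains why the chain length matters and the methyl group does not. As far as these compounds go, it also stays open whether a larger group on this carbon, such as an ethyl group or an amine, would read the same, and whether a carboxylic acid in place of the nitrile would follow the same trend with chain length.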